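Quinoline tetrazole series: methoxy for fluoro at the carbocyclic ring

The source may hold more compounds than are shown below. What is called first, only, known or untested is meant among the compounds shown, and "the series" means these compounds.

Measured so far:
compound 1, `CCc1cccc2cc(C(=O)O)cnc12`: > 50 mg/kg
compound 2, `Fc1ccc2ncc(-c3nn[nH]n3)cc2c1`: < 25 mg/kg

In a functional assay on the whole organism (strain Sprague-Dawley) for inhibition, with Rattus norvegicus as the target (a higher number here means that more compound is needed for the effect, a lower number that less compound is needed), compound 2 gives only a limit, < 25 mg/kg. In this assay compound 1 likewise gives only a limit, > 50 mg/kg. Among the measured compounds shown here, no step between measured compounds that differ in one place is available: the two results are the limit of < 25 mg/kg in this assay, at which 1 of the 2 values shown sits, for compound 2 and the limit of > 50 mg/kg in this assay, at which 1 of the 2 values shown sits, for compound 1, and nothing more can be read from the pair.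

The next compound, compound 3, `COc1ccc2ncc(-c3nn[nH]n3)cc2c1`, is not yet measured. It differs from compound 2 in one place: methoxy in place of fluoro on an aromatic carbon. The change sits on an aromatic carbon of a six-membered aromatic ring of carbon only, part of a fused or bridged system of two rings.

With compound 2 standing only at a limit, the expected step from compound 2 to compound 3, a step that the limit leaves unreadable from compound 2 to compound 3, is small and not beyond the scatter in either direction. For compound 3 the estimate in this assay is 15 mg/kg, with a range from 5 mg/kg to 50 mg/kg.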

Compound 3, minimum effective dose: 10 mg/kg
Beside the measured number, compound 3's estimate is 1.5-fold (0.18 log units) above it, within the range that was stated.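

In this assay compound 2 gives only a limit, < 25 mg/kg. Among the compounds shown here, compound 3 gives 10 mg/kg, and no step from compound 2 to compound 3 can be read from this pair. The compounds shown leave open the size and direction of the effect of methoxy in place of fluoro on an aromatic carbon.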